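The source may report more compounds than this note shows. Statements on the series, on what has been measured and on what is new or still open speak of the compounds shown alone.

Measured compounds:

- Compound 1 `Cn1ccc2c(Oc3ccc(NC(=O)c4cc5cccnc5n(-c5ccc(F)c(Cl)c5)c4=O)cc3)ccnc21`: 820 nM
- Compound 2 `Cn1ccc2c(Oc3ccc(NC(=O)c4cc5cccnc5n(-c5ccc(Br)cc5)c4=O)cc3F)ccnc21`: 390 nM

Of the compounds shown here, two have been tested in a functional assay on A549 cells (Homo sapiens) for antiproliferative activity, read by MTT assay, with a stated time of 72 h; a higher number here means a weaker inhibitor, a lower number a stronger inhibitor. Compound 1 gives 820 nM. Compound 2 gives 390 nM, the lower of the two numbers; compound 1 stands a step beyond the scatter above it. For the measured compounds named here, the two compounds differ in more than one place, so their values show only that compound 2 is the stronger inhibitor of this pair, not which part of the structure accounts for it.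

Compound 3 `Cn1ccc2c(Oc3ccc(NC(=O)c4cc5cccnc5n(-c5ccc(F)c(Cl)c5)c4=O)cc3F)ccnc21` has not yet been measured. It is reached from compound 2 by one change: 3-chloro-4-fluorophenyl in place of 4-bromophenyl on an aromatic nitrogen. The rest of compound 2, including the fluorine on the central ring, stays in place. Going by the values given here, the new aryl group is the one that compound 1 carries, and compound 1 sits above compound 2 in this assay, but compound 1 also lacks the fluorine on the central ring, so the data do not isolate the effect of the aryl group alone. The expected step from compound 2 to compound 3 is a 1.3-fold higher number from compound 2 to compound 3 (0.11 log units; within the scatter), a small change that may not clear the scatter. Compound 3 is therefore estimated at 500 nM, within a range from 200 nM to 1300 nM.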

Compound 3, half-maximal inhibitory concentration: 3560 nM
Estimate against measurement, compound 3: 7.1-fold (0.85 log units) below; measured number above the stated range.
By their numbers in this assay, from the lowest: compound 2; then compound 1; then compound 3.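

In this assay, the group on the aromatic nitrogen proves to matter a great deal: with everything else held fixed, 3-chloro-4-fluorophenyl in place of 4-bromophenyl gives a 9.1-fold higher number from compound 2 to compound 3 (0.96 log units; beyond the scatter), a loss of activity that compound 1 and compound 2 could not isolate, as they differ in more than one place. For the compounds shown here, the same result gives a first clean reading of the second site, where fluoro in place of hydrogen on an aromatic carbon, with 3-chloro-4-fluorophenyl on the nitrogen, gives a 4.3-fold higher number from compound 1 to compound 3 (0.64 log units; beyond the scatter), so in this pair the added fluorine goes with a weaker inhibitor. Nothing measured here offers an explanation for either step.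

The compounds shown leave open whether the fluoro step would run the same way with 4-bromophenyl on the nitrogen, as it is seen only with 3-chloro-4-fluorophenyl. They also leave open which feature of the two aryl groups tracks with activity, and how a phenyl ring carrying an amine or a methoxy group would behave on that aromatic nitrogen.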